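The source may hold more compounds than are shown below. What is called first, only, known or untested is meant among the compounds shown, and "the series" means these compounds.

Working notes on the benzoxazole sulfonamide series, cytotoxicity.

Compound 1 `O=S(=O)(Nc1ccc2oc(-c3ccccc3)nc2c1)c1ccccc1O` gives 33000 nM in an ADME assay on HEK293 cells (Homo sapiens) for cytotoxicity, read by resazurin assay, with a stated time of 48 h; a higher number here means that more compound is tolerated, a lower number that less compound is tolerated. Within the data shown here, compound 3 `O=S(=O)(Nc1ccc2oc(-c3ccccc3)nc2c1)c1ccccc1C(F)(F)F` gives 80000 nM in this assay, and the single measured step, a 2.4-fold higher number from compound 1 to compound 3 (0.38 log units; beyond the scatter), is the only paired comparison available. Compound 2 `COc1ccc(S(=O)(=O)Nc2ccc(-c3nc4ccccc4o3)cc2)cc1` sits at the top of the numbers shown: in this assay compound 2 gives > 100000 nM, which is a limit of the assay and not a number, at the limit of > 100000 nM in this assay, at which 1 of the 3 values shown sits.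

The next compound, compound 4 `Cc1cccc(S(=O)(=O)Nc2ccc(-c3nc4ccccc4o3)cc2)c1`, differs from compound 2 by 3-methylphenyl in place of 4-methoxyphenyl on a sulfonyl sulfur. Among the measured compounds shown here, no measured step covers this change; the one recorded step concerns trifluoromethyl in place of hydroxy and was modest, so it does not transfer to the change at the sulfonyl sulfur. With compound 2 already at the limit, the step from compound 2 to compound 4 is expected to be a number no higher from compound 2 to compound 4 (the limit leaves the size open), that is, no movement beyond the scatter. Compound 4 is therefore estimated at 100000 nM, with a range from 40000 nM to 250000 nM, and a fair chance that again only a limit is reported.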

Compound 4, half-maximal cytotoxic concentration: > 100000 nM
Compound 4: only a limit was reported (the forecaster's own chance of this, stated with the estimate: 55%); the middle value sits exactly at the limit.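

Compound 2 and compound 4 both stand at a limit in this assay and no step can be read between them: the limit of > 100000 nM in this assay, at which 2 of the 4 values shown sit.

From the compounds shown here alone, what stays open is how far either compound lies past that limit, and whether 3-methylphenyl in place of 4-methoxyphenyl on a sulfonyl sulfur shifts tolerance at all.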